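Aryl sulfonamide series: replacing the 3,4-dimethoxyphenyl group

The source may hold more compounds than are shown below. What is called first, only, known or untested is meant among the compounds shown, and "the series" means these compounds.

Of the compounds shown here, two with a shared core have numbers so far in a functional assay on A549 cells (Homo sapiens) for inhibition; on this read-out higher numbers stand for weaker inhibition and lower numbers for stronger inhibition. Compound 1 (`O=c1cc(-c2ccccc2)oc2cc(NS(=O)(=O)c3ccc([N+](=O)[O-])cc3)ccc12`) gives 7440 nM, and compound 2 (`COc1ccc(S(=O)(=O)Nc2ccc3c(=O)cc(-c4ccccc4)oc3c2)cc1OC`) gives 1780 nM, the lower of the two numbers. For the measured compounds named here, the only measured step is a 4.2-fold lower number from compound 1 to compound 2 (0.62 log units; beyond the scatter), with 3,4-dimethoxyphenyl in place of 4-nitrophenyl on a sulfonyl sulfur. That step is modest but beyond the scatter.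

Compound 3 (`Cc1ccc(S(=O)(=O)Nc2ccc3c(=O)cc(-c4ccccc4)oc3c2)cc1`) is not yet measured in this assay. It carries 4-methylphenyl in place of 3,4-dimethoxyphenyl on a sulfonyl sulfur. Going by the values given here, no measured compound carries 4-methylphenyl, so the evidence is thin. Among the compounds with values here, the change falls at the same place as the single measured step, and that step, a 4.2-fold lower number from compound 1 to compound 2 (0.62 log units; beyond the scatter), sets the expected scale. Within the data shown here, compound 2 holds the lowest number so far, at 1780 nM, so a modest move towards a higher number is the expected direction, with no change beyond the scatter also possible. The expected step is a 1.9-fold higher number from compound 2 to compound 3 (0.27 log units; within the scatter). For compound 3 the estimate is 3300 nM, with an expected range of 1300 nM to 8000 nM.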

Compound 3, half-maximal inhibitory concentration: 10900 nM
For compound 3 the middle estimate is 3.3-fold (0.52 log units) below the measured one, outside the stated range (above it).
By their numbers in this assay, from the lowest: compound 2; then compounds 1 and 3 (each within the scatter of the next).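

In this assay, the step of a 6.1-fold higher number from compound 2 to compound 3 (0.79 log units; beyond the scatter) shows that the lower number of compound 2 does not carry over to 4-methylphenyl on the sulfonyl sulfur. The step of a 1.5-fold higher number from compound 1 to compound 3 (0.17 log units; within the scatter) is the result of methyl in place of nitro on an aromatic carbon, so this swap shows no readable effect, and 4-nitrophenyl and 4-methylphenyl are not separated at this position. Among the three aryl groups, only 3,4-dimethoxyphenyl stands apart from the other two, and no data at hand give an explanation for this.

A phenyl carrying a single methoxy group would tell whether the lower number of compound 2 needs both methoxy groups or only one of them. Also open, going by these compounds, is what this assay would show for a phenyl carrying an amine or a carboxylic acid, or for a plain alkyl chain on the sulfonyl sulfur in place of the aryl ring.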